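A few compounds are considered here, and "the series" means these few. Any claim that something is new, unique, unknown or untested is made for them only; others in the source may bear on it.

Compound 2 `Cc1cc(Cl)ccc1CC(C)C(=O)N1CCN(c2ccc(C(F)(F)F)cc2[C@@H](N)CC(C)C)CC1` gives 38 nM in an assay on HEK293 cells for displacement of a labelled ligand from Melanocortin receptor 4 (Homo sapiens) (on this read-out higher numbers stand for weaker inhibition and lower numbers for stronger inhibition), the lowest of the two numbers measured, while compound 1 `Cc1ccc(CC(C)C(=O)N2CCN(c3ccc(C(F)(F)F)cc3[C@@H](N)CC(C)C)CC2)cc1C` gives 240 nM. Among the compounds with values here, the one measured step, a 6.3-fold lower number from compound 1 to compound 2 (0.80 log units; beyond the scatter), shows that changing the aromatic part of this side group already shifts the number beyond the scatter. Compound 3 `CC(C)C[C@H](N)c1cc(C(F)(F)F)ccc1N1CCN(C(=O)CCC(=O)N(C)C)CC1` differs from compound 2 by 2-(dimethylcarbamoyl)ethyl in place of 1-(4-chloro-2-methylbenzyl)ethyl on a carbonyl carbon. Within the data shown here, no measured step covers losing the aromatic ring altogether, so compound 3 is expected to give a higher number, a step of a 66-fold higher number from compound 2 to compound 3 (1.82 log units; beyond the scatter). Compound 3 is estimated at 2500 nM, between 400 nM and 15000 nM.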

Compound 3, inhibition constant: > 10000 nM
Compound 3 was reported as a limit; the forecaster's own chance of this, stated with the estimate: 20%; middle value at least 4.0-fold (0.60 log units) from the limit.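

In this assay, compound 3 gives a limit rather than a number: the limit of > 10000 nM in this assay, at which 1 of the 3 values shown sits.

Placing 2-(dimethylcarbamoyl)ethyl on this carbonyl carbon gives an at least 260-fold higher number from compound 2 to compound 3 (2.42 log units; beyond the scatter), and in place of the other side group it gives an at least 41-fold higher number from compound 1 to compound 3 (1.61 log units; beyond the scatter). Whereas the earlier step changed only the substituents on the aromatic ring, these steps show that this position does not tolerate exchanging the whole ring-bearing group for this ring-free chain.

Each step removes the ring and adds the dimethylcarbamoyl end at once, leaving their separate contributions unresolved. From the compounds shown here alone, a plain propyl chain, or a chain ending in an amine or a carboxylic acid, remains open.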